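Epimer at the Ring Carbon: Expected Stability of Compound 4

The compounds below may be only part of what the source reports. "The series", "measured", "known", "first", "only" and "open" are said of these compounds alone.

Compound 1, `CC(OC(=O)O[C@H]1CCCCc2ccccc21)OC(=O)C1=C(S[C@@H]2CN[C@H](C(=O)N(C)C)C2)[C@H](C)[C@@H]2[C@@H]([C@@H](C)O)C(=O)N12`, gives 1.33 h.
Compound 2, `C[C@@H](O)[C@H]1C(=O)N2C(C(=O)OCOC(=O)O[C@H]3CCCc4ccccc43)=C(S[C@@H]3CN[C@H](C(=O)N(C)C)C3)[C@H](C)[C@H]12`, gives 0.015 h.
Compound 3, `CC(=O)N1C[C@@H](SC2=C(C(=O)OCOC(=O)O[C@H]3CCCCc4ccccc43)N3C(=O)[C@H]([C@@H](C)O)[C@H]3[C@H]2C)C[C@H]1C(=O)N(C)C`, gives 0.467 h.

These three compounds were tested in a physicochemical assay for metabolic stability, read by HPLC, at pH 6, tested at 100 uM; on this read-out lower numbers stand for a shorter-lived compound and higher numbers for a longer-lived compound. Compound 2 stands at the bottom of the three numbers: its nearest neighbour is compound 3, whose value is beyond the scatter above it, and compound 1 lies further still, also beyond the scatter. So compound 2 is the shortest-lived of the three measured compounds by a clear margin.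

Compound 4, `C[C@@H](O)[C@H]1C(=O)N2C(C(=O)OCOC(=O)O[C@@H]3CCCc4ccccc43)=C(S[C@@H]3CN[C@H](C(=O)N(C)C)C3)[C@H](C)[C@H]12`, is the next compound to be tested in this assay. It is the closest possible relative of compound 2: the two compounds have the same atoms and bonds and differ only in configuration as drawn: 1 of 7 stereo elements differ; a stereocentre at a saturated ring carbon is drawn S in compound 2 and R in compound 4. Nothing is added or removed; only the spatial arrangement at that one ring carbon is flipped.

For the measured compounds named here, no pair of measured compounds shows what such a single stereochemical inversion does here, so the step must be guessed. A change of configuration alone, with everything else the same, is expected to move the half-life only modestly, if at all; the step of a 2.0-fold higher number from compound 2 to compound 4 (0.30 log units; within the scatter) is expected to stay within or just beyond the usual scatter. Compound 4 is therefore estimated at 0.03 h, with a plausible range from 0.008 h to 0.15 h.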

Compound 4, half-life: 0.016 h
Compound 4: the middle estimate sits 1.9-fold (0.27 log units) above what was measured; low and high end bracket the measured number.
By their numbers in this assay, from the lowest: compounds 2 and 4 (each within the scatter of the next); then compound 3; then compound 1.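

In this assay, inverting the stereocentre at a saturated ring carbon from S to R gives a 1.1-fold higher number from compound 2 to compound 4 (0.03 log units; within the scatter), so at this position the change of configuration has no effect that this measurement can distinguish from ordinary scatter. For the compounds shown here, none of the earlier compounds differed from one another in only one place, so they could not isolate the effect of any single change, whereas this pair can tie its result to that one centre, and compound 4 at 0.016 h remains as short-lived as compound 2. The comparison is unusually direct, as the result rests on a single structural fact: the fact that compounds 2 and 4 differ only in the configuration as drawn

Going by these compounds, whether the same inversion would be equally silent in the longer-lived compound 1 or compound 3 remains open, since one pair speaks only for its own structures. Also open, on these data alone, is how the half-life would respond if a methoxy group or a fluorine atom were placed at that ring carbon, a change of substituent rather than of configuration.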